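This account rests on a few compounds, and the source may have more. Where it says the series, first, only, none or still open, it means among the compounds named here.

Measured compounds:
- compound 1 `CC(C)n1ncc2c(C(=O)NCc3cn(-c4cccc(Br)c4)nn3)cccc21` — > 40000 nM
- compound 2 `Cc1ccccc1-n1cc(CNC(=O)c2cccc3c2cnn3C(C)C)nn1` — > 40000 nM

In a functional assay on HepG2 cells (Homo sapiens) for inhibition, read by MTT assay, with a stated time of 72 h (on this read-out higher numbers stand for weaker inhibition and lower numbers for stronger inhibition), compound 2 returns only a limit of the assay, > 40000 nM. Compound 1 likewise gives only a limit in this assay, > 40000 nM. Among the compounds with values here, the single measured step between them, a step that the two limits leave unreadable from compound 1 to compound 2, cannot be sized because of the limit of > 40000 nM in this assay, at which 2 of the 2 values shown sit; the two readings say only that neither compound reaches measurable inhibition within the tested range.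

Compound 3 `COc1ccc(Cn2cc(CNC(=O)c3cccc4c3cnn4C(C)C)nn2)cc1` is the next compound to be examined in this assay. Its difference from compound 2 is 4-methoxybenzyl in place of 2-methylphenyl on an aromatic nitrogen. Within the data shown here, no measured step bears readably on this change: the only step in hand is unreadable, and both measured values sit at the limit. Nothing in the data therefore points to a step in either direction beyond the scatter, and the expectation is that compound 3 stays at or near the same limit. On that basis compound 3 is estimated at 40000 nM, with a range from 12000 nM to 130000 nM. This estimate corresponds to a number no higher from compound 2 to compound 3 (the limit leaves the size open), which is expected to be no change that could be read against the limit.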

Compound 3, half-maximal inhibitory concentration: > 40000 nM
Compound 3: only a limit was reported; the forecaster's own chance of this, stated with the estimate: 80%; the middle value sits exactly at the limit.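

No step among compound 1, compound 2 and compound 3 can be read in this assay, because each of them returns only a limit: the limit of > 40000 nM in this assay, at which 3 of the 3 values shown sit.

The compounds shown leave open whether any other group on this aromatic nitrogen, or any change to the shared core, would give a measurable inhibition of these cells.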